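The compounds below may be only part of what the source reports. "The series", "measured", "known", "first", "only" and "open" are said of these compounds alone.

Compound 2 `O=S(=O)(NCCCNCc1ccc(Br)cc1)c1cc(C(F)(F)F)cc(C(F)(F)F)c1` shares its core with compound 1 `O=S(=O)(NCCCNCc1ccccc1)c1cc(C(F)(F)F)cc(C(F)(F)F)c1` and carries bromo on an aromatic carbon. In a functional assay on MCF7 cells (Homo sapiens) for inhibition, read by MTT assay, with a stated time of 72 h (a lower number here means a stronger inhibitor of growth, a higher number a weaker inhibitor of growth), compound 1 gives 3000 nM, and in this assay compound 2 gives 1900 nM, the lower of the two numbers shown, although the gap to compound 1 lies within the scatter. Compound 3 `O=S(=O)(NCCCNCc1ccc(-c2ccccc2)cc1)c1cc(C(F)(F)F)cc(C(F)(F)F)c1` differs from compound 2 by phenyl in place of bromo on an aromatic carbon. Among the compounds with values here, only one measured step touches this position: a 1.6-fold lower number from compound 1 to compound 2 (0.20 log units; within the scatter). Within the data shown here, that step was small, so the one change made at this carbon so far moved the number little; no measured step involves phenyl, and the size of the step to compound 3 is therefore uncertain. A step about as small, in either direction or none beyond the scatter, is expected for a 1.3-fold lower number from compound 2 to compound 3 (0.10 log units; within the scatter). Compound 3 is accordingly estimated at 1500 nM in this assay, with a range from 500 nM to 5000 nM.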

Compound 3, concentration for 50% growth inhibition: 1700 nM
For compound 3 the middle estimate is 1.1-fold (0.05 log units) below the measured one, within the range that was stated.
By their numbers in this assay, from the lowest: compounds 3, 2 and 1 (each within the scatter of the next).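

In this assay, this aromatic carbon, para to a large group, now carries six heavy atoms in place of one, and the exchange of bromo for phenyl gives a 1.1-fold lower number from compound 2 to compound 3 (0.05 log units; within the scatter). Set against hydrogen at the same carbon, phenyl gives a 1.8-fold lower number from compound 1 to compound 3 (0.25 log units; within the scatter), so hydrogen, bromo and phenyl all lie within the scatter of one another, and neither the single atom nor the added six-membered aromatic ring separates from the others here. No further evidence bears on this result.

As far as these compounds go, what an amine or a carboxylic acid on this carbon would give remains open, so these three compounds cannot show whether any group here moves the number beyond the scatter. Also open, from the compounds shown here alone, is whether a longer chain in place of phenyl would behave in the same way.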